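A few compounds are considered here, and "the series" means these few. Any claim that something is new, unique, unknown or untested is made for them only; others in the source may bear on it.

Compound 1, `CCC1=C(O)c2c(oc(-c3cccc(F)c3)cc2=O)C(CC)(CC)C1=O`: in a functional assay on KB cells (Homo sapiens) for antiproliferative activity, read by sulforhodamine B assay, with a stated time of 3 days (a higher number here means that more compound is needed for the effect, a lower number that less compound is needed), compound 1 gives only a limit, > 56.2 uM.
Compound 2, `CCC1=C(O)c2c(oc(-c3ccccc3OC)cc2=O)C(CC)(CC)C1=O`: in this assay compound 2 gives 40.8 uM.

Compound 2 holds the only number shown in this assay; the remaining value is a limit, (the limit of > 56.2 uM in this assay, at which 1 of the 2 values shown sits). Compound 3 is `CCC1=C(O)c2c(oc(-c3cc(C)c(O)c(C)c3)cc2=O)C(CC)(CC)C1=O`, and the change from compound 2 to compound 3 is 4-hydroxy-3,5-dimethylphenyl in place of 2-methoxyphenyl on an aromatic carbon. Among the compounds with values here, the one measured step, an at least 1.3-fold lower number from compound 1 to compound 2 (0.13 log units; that floor lies within the scatter), reaches only a floor and does not touch the entering group, so no step beyond the scatter is foreseen in this assay. Compound 3 is estimated at 30 uM, with a range from 8 uM to 90 uM, the expected step being a 1.4-fold lower number from compound 2 to compound 3 (0.13 log units; within the scatter).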

Compound 3, concentration for half-maximal effect: 18.3 uM
Estimate against measurement, compound 3: 1.6-fold (0.21 log units) above, and the stated range covers the measured number.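

In this assay, within the data shown here, 4-hydroxy-3,5-dimethylphenyl in place of 2-methoxyphenyl gives a 2.2-fold lower number from compound 2 to compound 3 (0.35 log units; beyond the scatter) and is the first step at this position on the shared core to lie clearly beyond the scatter. In place of 3-fluorophenyl, the same group gives an at least 3.0-fold lower number from compound 1 to compound 3 (0.48 log units; beyond the scatter) as a floor only. The entry for compound 1 is a limit and not a number: the limit of > 56.2 uM in this assay, at which 1 of the 3 values shown sits.

From the compounds shown here alone, whether the step follows the hydroxy group or the two methyl groups stays open. Going by these compounds, the effect of an amine or a carboxylic acid on this phenyl ring also stays open.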